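Pyridin-2-yl in place of the pyrazolyl group

This account rests on a few compounds, and the source may have more. Where it says the series, first, only, none or still open, it means among the compounds named here.

Compound 2 `Cc1nn(-c2ccccc2)cc1/C=N/Nc1nc(Nc2ccccc2)nc(Nc2ccc(S(N)(=O)=O)cc2)n1` is known only by a limit in a functional assay on Hs-578T cells (Homo sapiens) for inhibition, read by sulforhodamine B assay, with a stated time of 48 h; on this read-out lower numbers stand for higher toxicity in this test and higher numbers for lower toxicity in this test. In this assay compound 2 gives > 100000 nM, which is a limit and not a number. Compound 1 `NS(=O)(=O)c1ccc(Nc2nc(N/N=C/c3ccc(C(F)(F)F)cc3)nc(Nc3ccccc3)n2)cc1` likewise gives > 100000 nM in this assay, again a limit. Among the compounds with values here, the single measured step, a step that the two limits leave unreadable from compound 1 to compound 2, therefore cannot be read, and the limit of > 100000 nM in this assay, at which 2 of the 2 values shown sit, is all the evidence the series holds. Compound 3 `NS(=O)(=O)c1ccc(Nc2nc(N/N=C/c3ccccn3)nc(Nc3ccccc3)n2)cc1` differs from compound 2 by pyridin-2-yl in place of 3-methyl-1-phenyl-1H-pyrazol-4-yl on a carbon with a double bond to nitrogen. Within the data shown here, no measured step bears on this change beyond the two limits, so no shift beyond the scatter is expected in this assay, and compound 3 is expected to sit at the same limit, with a number no higher from compound 2 to compound 3 (the limit leaves the size open) as the estimated step. The estimate for compound 3 is 100000 nM, within 30000 nM to 300000 nM.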

Compound 3, concentration lethal to 50% of the cells: > 100000 nM
Compound 3: a limit, no number (the forecaster's own chance of this, stated with the estimate: 75%); the middle value lies on the limit itself.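

No new step can be read: compound 1, compound 2 and compound 3 each stand only at a limit, not a number, in this assay. The compounds shown leave open whether pyridin-2-yl, 3-methyl-1-phenyl-1H-pyrazol-4-yl and 4-(trifluoromethyl)phenyl differ at all on this read-out.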